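Phenyl for Methoxy on the Urea Aryl Ring

This account rests on a few compounds, and the source may have more. Where it says the series, first, only, none or still open, it means among the compounds named here.

Compound 1, `CCc1ccccc1C(=O)OC(CCN(C)C)c1ccc(Cl)cc1`: 128%
Compound 2, `Cc1ccccc1NC(=O)NC(CCN(C)C)c1ccc(Cl)cc1`: 175%
Compound 3, `COc1ccc(NC(=O)NC(CCN(C)C)c2ccc(Cl)cc2)cc1`: 195%

Three compounds sharing a dimethylaminopropyl chain and a chlorophenyl group have been measured in an assay on NIH3T3 cells with Urotensin-2 receptor (Homo sapiens) as the target; a lower number here means a smaller maximal response, a higher number a larger maximal response. Compound 3 stands highest of the three. Its nearest neighbour is compound 2, and the step of a number 20 percentage points higher from compound 2 to compound 3 (beyond the scatter) lies beyond the scatter. Compound 1 is the furthest away: with its ester linkage in place of the urea it gives 128%, while compound 3 gives 195%.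

The next compound, compound 4, `CN(C)CCC(NC(=O)Nc1ccc(-c2ccccc2)cc1)c1ccc(Cl)cc1`, changes the aryl ring of the urea again. phenyl in place of methoxy on an aromatic carbon

Among the compounds with values here, only one measured step bears on this change, a number 20 percentage points higher from compound 2 to compound 3 (beyond the scatter), and it concerns a different pair of substituents on the same ring. Within the data shown here, no step shows what phenyl does in place of methoxy at this position. Among the measured compounds shown here, the one known step on this ring was modest, so a step of similar or smaller size is expected for compound 4, and its direction is not settled by the data. The estimate for compound 4 is therefore placed close to compound 3, at 190%, with a range from 150% to 230%, which corresponds to an expected step of a number 5 percentage points lower from compound 3 to compound 4 (within the scatter) within the scatter.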

Compound 4, largest response reached (reported as efficacy), in percent of the reference or control that the assay uses: 91%
Beside the measured number, compound 4's estimate is 99 percentage points above it, outside the stated range (below it).
By their numbers in this assay, from the lowest: compound 4; then compound 1; then compound 2; then compound 3.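

Within the data shown here, on this ring, the position para to a large group proves far more sensitive than the earlier compounds could show: in this assay, replacing methoxy with phenyl gives a number 104 percentage points lower from compound 3 to compound 4 (beyond the scatter) and reverses the direction of the only earlier step on this ring, a number 20 percentage points higher from compound 2 to compound 3 (beyond the scatter), while also far exceeding it in size. The high maximal response seen with compound 3 therefore does not carry over to every group placed there, and this single exchange is enough to remove it. The change swaps 2 heavy atoms and 1 hydrogen-bond acceptor for 6 heavy atoms, a six-membered aromatic ring of carbon only and no hydrogen-bond acceptor, but nothing shown gives a measured basis for explaining the fall in response.

With all of these differences arriving together, the compounds shown do not separate the contribution of the added ring from that of losing the methoxy oxygen. As far as these compounds go, it also remains open how a chlorine atom, a dimethylamino group, a carboxylic acid or a benzyloxy group at this place would compare with methoxy and phenyl in this assay, and whether phenyl would have the same effect elsewhere on the ring.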